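Cyano in place of chloro: what to expect

A few compounds are considered here, and "the series" means these few. Any claim that something is new, unique, unknown or untested is made for them only; others in the source may bear on it.

Measured in a functional assay on MKN-45 cells (Homo sapiens) for inhibition, read by CCK-8 assay, with a stated time of 24 h; on this read-out higher numbers stand for weaker inhibition and lower numbers for stronger inhibition:
- compound 1 `Cc1ccccc1-n1cc(-c2ccc(/C=C3\C(=O)Nc4ccccc43)cc2)nn1`: 9770 nM
- compound 2 `O=C1Nc2ccccc2/C1=C/c1ccc(-c2cn(-c3ccccc3F)nn2)cc1`: 12500 nM
- compound 3 `O=C1Nc2ccccc2/C1=C/c1ccc(-c2cn(-c3cccc(Cl)c3)nn2)cc1`: > 20000 nM (a limit, not a number)

Compound 3 stands at the limit of > 20000 nM in this assay, at which 1 of the 3 values shown sits. Compound 4 `N#Cc1cccc(-n2cc(-c3ccc(/C=C4\C(=O)Nc5ccccc54)cc3)nn2)c1` differs from it in one place: cyano in place of chloro on an aromatic carbon. In words, this is cyano in place of chloro on an aromatic carbon, meta to a large group, or 3-chlorophenyl to 3-cyanophenyl.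

For the measured compounds named here, no measured step makes this exact exchange. The nearest evidence comes from the steps that arrive at the 3-chlorophenyl group: an at least 2.0-fold higher number from compound 1 to compound 3 (0.31 log units; beyond the scatter), and an at least 1.6-fold higher number from compound 2 to compound 3 (0.20 log units; that floor lies within the scatter). Both rest on a limit, so they give only the smallest possible size of each step. Another exchange of one group for another gave a 1.3-fold higher number from compound 1 to compound 2 (0.11 log units; within the scatter).

A small step to a lower number is therefore expected in this assay, though a second reading at the limit remains quite possible. The expected step is an at least 1.1-fold lower number from compound 3 to compound 4 (0.07 log units; that floor lies within the scatter), which is only an estimate. For compound 4 the estimated value is 17000 nM, with an expected range of 8000 nM to 35000 nM.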

Compound 4, half-maximal inhibitory concentration: > 20000 nM
Compound 4 gave a limit, no number; the forecaster's own chance of this, stated with the estimate: 45%; at least 1.1-fold (0.07 log units) between middle value and limit.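

In this assay, the 3-cyanophenyl group of compound 4 ends at a limit of the assay, as the 3-chlorophenyl group of compound 3 does, so cyano in place of chloro at this position does not bring back a readable number: the limit of > 20000 nM in this assay, at which 2 of the 4 values shown sit.

Against the two compounds that give numbers, the data now show an at least 2.0-fold higher number from compound 1 to compound 4 (0.31 log units; beyond the scatter) and an at least 1.6-fold higher number from compound 2 to compound 4 (0.20 log units; that floor lies within the scatter). The step between the two limits cannot be read, so this exchange has no measurable size here.

On these data alone, how far compound 3 and compound 4 lie past the limit stays open, and so does any order between them. Also open, as far as these compounds go, is whether an amine or a carboxylic acid in place of the cyano would give a readable number in this assay.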